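A few compounds are considered here, and "the series" means these few. Any claim that something is new, unique, unknown or untested is made for them only; others in the source may bear on it.

Of the compounds shown here, three that share one core have been tested in a functional assay on CHO.K1 cells for antagonist activity at prostaglandin D2 receptor 2 (Homo sapiens), read by GTPgammaS binding, with a stated time of 1 h; on this read-out lower numbers stand for stronger inhibition and higher numbers for weaker inhibition. Compound 3 `Cc1c(Cc2ccccc2S(=O)(=O)c2cccc(Cl)c2)c2c(n1CC(=O)O)CCNC2=O` gives 4 nM in this assay, the lowest number of the three. Nearest to it is compound 1 `CNC(=O)c1ccc(Cc2c3c(n(CC(=O)O)c2C)CCNC3=O)c(S(=O)(=O)c2ccccc2)c1`, which gives 10 nM in this assay, a gap that lies beyond the usual scatter of repeated measurements. Furthest from it is compound 2 `COc1cccc(S(=O)(=O)c2ccccc2)c1Cc1c2c(n(CC(=O)O)c1C)CCNC2=O`, which gives 4500 nM in this assay, a far wider gap. No two of these three compounds differ in only one place, so none of the gaps can be tied to a single structural change.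

Compound 4 `COc1ccc(S(=O)(=O)c2ccccc2Cc2c3c(n(CC(=O)O)c2C)CCNC3=O)cc1` has not yet been measured. It differs from compound 3 in one place: 4-methoxyphenyl in place of 3-chlorophenyl on a sulfonyl sulfur. For the measured compounds named here, no measured pair shows this change, so any expectation must rest on the spread of numbers seen so far, and that spread gives no firm guide for a change on the sulfonyl sulfur. The step from compound 3 to compound 4 is expected to be a 2.5-fold higher number from compound 3 to compound 4 (0.40 log units; beyond the scatter), a small weakening that barely reaches beyond the scatter. Compound 4 is therefore estimated to give about 10 nM in this assay, with a likely range from 3 nM to 40 nM.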

Compound 4, half-maximal inhibitory concentration: 3.9 nM
Beside the measured number, compound 4's estimate is 2.6-fold (0.41 log units) above it; the range from low to high includes it.
By their numbers in this assay, from the lowest: compounds 4 and 3 (each within the scatter of the next); then compound 1; then compound 2.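

In this assay, for the compounds shown here, putting 4-methoxyphenyl in place of 3-chlorophenyl on a sulfonyl sulfur gives a 1.0-fold lower number from compound 3 to compound 4 (0.01 log units; within the scatter), the first comparison in this set that isolates a change in one place. At this position, the two substituted phenyl groups therefore cannot be told apart by this read-out, even though one carries chlorine and the other a methoxy group. This single exchange alters both the group on the ring and the place it occupies. It shows only how this particular pair compares, not what either alteration does alone. No measurement is available that would explain the match.

The compounds shown leave open how 4-chlorophenyl or 3-methoxyphenyl would compare on the same sulfonyl sulfur, and such a pair could separate the effect of the group from that of its place on the ring. Also open, from the compounds shown here alone, is how far this position's apparent tolerance extends, for example to an amine or a carboxylic acid on the phenyl ring, or to a simple methyl group in place of the ring.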